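A few compounds are considered here, and "the series" means these few. Any claim that something is new, unique, unknown or untested is made for them only; others in the source may bear on it.

Of the compounds shown here, two of a shared core have been measured in a functional assay on HepG2 cells (Homo sapiens) for cytotoxicity, read by MTT assay, with a stated time of 48 h; a higher number here means a weaker inhibitor, a lower number a stronger inhibitor. Compound 1 `NNC(=O)CSc1nnc(-c2ccncc2)o1` gives 3260 nM in this assay. Compound 2 `O=C(CSc1nnc(-c2ccncc2)o1)N/N=C/c1ccccc1O` gives 3510 nM, a number that sits within the scatter of compound 1, so the two cannot be ranked against each other. Compound 3 `O=C(CSc1nnc(-c2ccncc2)o1)N/N=C/C=C/c1ccccc1` has not yet been measured; it differs from compound 2 in one place: 2-phenylethenyl in place of 2-hydroxyphenyl on a carbon with a double bond to nitrogen. Among the measured compounds shown here, with no measured step as a guide, the step from compound 2 to compound 3 is expected to be small, a 1.0-fold lower number from compound 2 to compound 3 (0.00 log units; within the scatter), in either direction or none beyond the scatter. Compound 3 is therefore estimated at 3500 nM, between 1500 nM and 8000 nM.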

Compound 3, half-maximal inhibitory concentration: 7420 nM
Compound 3: middle estimate off by 2.1-fold (0.33 log units), on the low side; the measured number falls inside the stated range.
By their numbers in this assay, from the lowest: compounds 1 and 2 (each within the scatter of the next); then compound 3.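

Among the compounds shown here, this is the first measured change at this place, on a carbon with a double bond to nitrogen, and it shows that the group there can shift the number in this assay: 2-phenylethenyl in place of 2-hydroxyphenyl gives a 2.1-fold higher number from compound 2 to compound 3 (0.33 log units; beyond the scatter), a modest loss of strength. The entering group has no hydrogen-bond donors or acceptors and brings a double bond outside the ring, and this single step cannot separate those differences. No measurement here explains the shift. On these data alone, whether an amine or a carboxylic acid on the aromatic ring of compound 2, or a longer chain in place of 2-phenylethenyl, would lower or raise the number remains open.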